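The compounds below may be only part of what the source reports. "The series", "measured", "known", "first", "only" and "open" are said of these compounds alone.

Measured so far:
- compound 1, `O=C1OC[C@H](Cc2ccccc2)[C@H]1Cc1cccc(OC(F)(F)F)c1`: in a functional assay on HL-60 cells (Homo sapiens) for cytotoxicity, read by WST assay, with a stated time of 48 h (on this read-out higher numbers stand for an effect only at larger amounts of compound and lower numbers for an effect already at smaller amounts), compound 1 gives 34000 nM
- compound 2, `O=C1OC[C@H](Cc2ccccc2)[C@H]1Cc1cccc(Cl)c1`: in this assay compound 2 gives 36000 nM

Among the compounds with values here, compound 2 holds the highest of the two numbers, but its only neighbour, compound 1, sits within the scatter of it: a 1.1-fold higher number from compound 1 to compound 2 (0.02 log units; within the scatter). So the two measured compounds cannot be told apart on this read-out.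

Compound 3, `O=C1OC[C@H](Cc2ccccc2)[C@H]1Cc1ccc(F)cc1`, has not been measured yet. It differs from compound 2 in one place:
4-fluorophenyl in place of 3-chlorophenyl on a saturated chain carbon bound to a saturated ring carbon

Within the data shown here, only one measured step exists, and it is also an exchange of one group for another on an aromatic carbon, going from compound 1 to compound 2: a 1.1-fold higher number from compound 1 to compound 2 (0.02 log units; within the scatter). That step changed the number only within the scatter. With a single step of this kind to go on, the expectation for compound 3 in this assay is a number close to that of compound 2, with no step beyond the scatter in either direction.

The estimated step is no change at the digits printed from compound 2 to compound 3 (within the scatter). Compound 3 is therefore expected to give about 36000 nM, within a range from 15000 nM to 90000 nM.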

Compound 3, half-maximal effective concentration: 57000 nM
For compound 3 the middle estimate is 1.6-fold (0.20 log units) below the measured one; the measured number falls inside the stated range.
By their numbers in this assay, from the lowest: compounds 1, 2 and 3 (each within the scatter of the next).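

In this assay, within the data shown here, the earlier step exchanged only one group on an aromatic carbon, whereas this change replaces 3-chlorophenyl with 4-fluorophenyl on a saturated chain carbon bound to a saturated ring carbon, so the atom on the ring and its place on the ring differ at once, and the outcome is a 1.6-fold higher number from compound 2 to compound 3 (0.20 log units; within the scatter). This adds a second kind of change that does not separate two compounds on this read-out, so 3-chlorophenyl and 4-fluorophenyl cannot be told apart at this position. No measurement is available that would explain this result.

Since the atom and its place differ together, the compounds shown cannot say what either exchange would do alone, and a step in one could be offset by a step in the other. Going by these compounds, it also remains open whether a more different group at this position, such as an amine or a carboxylic acid on the phenyl ring, or a longer chain leading to that ring, would move the number beyond the scatter.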